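The source may report more compounds than this note shows. Statements on the series, on what has been measured and on what is new or still open speak of the compounds shown alone.

Compound 1 `Oc1cccc(-c2cc(-c3cccc(F)c3)cc(-c3ccccc3O)n2)c1`: in a functional assay on HCT-15 cells (Homo sapiens) for inhibition (on this read-out higher numbers stand for weaker inhibition and lower numbers for stronger inhibition), compound 1 gives > 50000 nM, which is a limit of the assay.
Compound 2 `Oc1ccc(-c2cc(-c3cccc(F)c3)cc(-c3ccccc3O)n2)cc1`: in this assay compound 2 gives > 50000 nM, which is also a limit of the assay.
Compound 3 `Oc1ccc(-c2cc(-c3ccccc3F)cc(-c3cccc(O)c3)n2)cc1`: in this assay compound 3 gives 5630 nM.

Compound 3 stands as the only numbered result in this assay; the other two values sit at the limit (the limit of > 50000 nM in this assay, at which 2 of the 3 values shown sit). Among the measured compounds shown here, the one step between compounds that differ in a single place, a step that the two limits leave unreadable from compound 1 to compound 2, is unreadable from two limits and gives no size.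

Compound 4 `Oc1ccc(-c2cc(-c3cccc(F)c3)cc(-c3cccc(O)c3)n2)cc1` remains to be measured in this assay. It differs from compound 3 by 3-fluorophenyl in place of 2-fluorophenyl on an aromatic carbon. For the measured compounds named here, no measured step bears on this change: the only measured step concerns the hydroxyphenyl groups, not the fluorophenyl group. Going by the values given here, compound 1 and compound 2 each carry a 3-fluorophenyl group, but each differs from compound 4 in more than one place and each gives only a limit, so they set no size for the step. The expectation therefore rests on compound 3 alone, with a wide range for the unmeasured change and a lean toward weaker inhibition. Compound 4 is expected to give 12000 nM, with a range of 3500 nM to 50000 nM. The step from compound 3 to compound 4 is estimated as a 2.1-fold higher number from compound 3 to compound 4 (0.33 log units; beyond the scatter), close to the scatter.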

Compound 4, half-maximal inhibitory concentration: 3070 nM
Compound 4: the middle estimate sits 3.9-fold (0.59 log units) above what was measured; the measured number lies below the stated range.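

At the fluorophenyl position, opposite the ring nitrogen, 3-fluorophenyl in place of 2-fluorophenyl gives a 1.8-fold lower number from compound 3 to compound 4 (0.26 log units; within the scatter) in this assay, so this pair does not separate the two fluorophenyl groups. The hydroxyphenyl groups carry the large steps: with 3-hydroxyphenyl in place of 2-hydroxyphenyl there is an at least 16-fold lower number from compound 2 to compound 4 (1.21 log units; beyond the scatter), and with 4-hydroxyphenyl in place of 2-hydroxyphenyl there is an at least 16-fold lower number from compound 1 to compound 4 (1.21 log units; beyond the scatter), so among the four compounds shown, the two carrying 2-hydroxyphenyl are the two without a numbered result. The step between compound 1 and compound 2 cannot be read, and the two large steps start from limits of the assay, which makes their sizes minimum values: the limit of > 50000 nM in this assay, at which 2 of the 4 values shown sit.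

From the compounds shown here alone, whether the fluorine itself contributes at this position remains open, and a plain phenyl group or a trifluoromethyl group in its place would address that. Also open, going by these compounds, is whether the hydroxyl on either hydroxyphenyl group of compound 4 can give way to an amine or a methoxy group while the number stays in the range of compound 4 and compound 3.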